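This account rests on a few compounds, and the source may have more. Where it says the series, first, only, none or still open, it means among the compounds named here.

Working notes on the series.

Among the compounds with values here, compound 1 `CCCCc1ccc(-c2cc(N3CCC(CNS(N)(=O)=O)CC3)ncn2)cc1` stands second highest of the three numbers so far in a functional assay on HT-29 cells (Homo sapiens) for antiproliferative activity, read by sulforhodamine B assay, with a stated time of 48 h (a higher number here means a weaker inhibitor of growth, a lower number a stronger inhibitor of growth), where compound 1 gives 15200 nM. Its nearest neighbour is compound 2 `CC(C)(C)c1ccc(-c2cc(N3CCC(CNS(N)(=O)=O)CC3)ncn2)cc1`, which in this assay gives 8900 nM, with a 1.7-fold lower number from compound 1 to compound 2 (0.23 log units; within the scatter). Furthest is compound 3 `NS(=O)(=O)NCC1CCN(c2cc(-c3ccc(C(F)(F)F)cc3)ncn2)CC1`, which in this assay gives 29100 nM, with a 1.9-fold higher number from compound 1 to compound 3 (0.28 log units; within the scatter). Between the other two, a 3.3-fold higher number from compound 2 to compound 3 (0.51 log units; beyond the scatter).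

Compound 4 `COC(=O)c1ccc(-c2cc(N3CCC(CNS(N)(=O)=O)CC3)ncn2)cc1` is not yet measured. Relative to compound 1 the change is methoxycarbonyl in place of butyl on an aromatic carbon. All three measured steps exchange the group on that same aromatic carbon, and two of the three stay within the scatter while the third is only modest. On that basis the step from compound 1 to compound 4 in this assay is expected to be small, most likely not beyond the scatter, with a slight lean toward a higher number given that compound 3 sits at 29100 nM. Compound 4 is therefore estimated at 20000 nM in this assay, within a range of 7000 nM to 60000 nM. The expected step is a 1.3-fold higher number from compound 1 to compound 4 (0.12 log units; within the scatter).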

Compound 4, concentration for 50% growth inhibition: 22900 nM
The estimate for compound 4 lay 1.1-fold (0.06 log units) below the measured number, within the range that was stated.
By their numbers in this assay, from the lowest: compounds 2, 1, 4 and 3 (each within the scatter of the next, the first and the last beyond it).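

In this assay, the exchange of butyl for methoxycarbonyl keeps the heavy-atom count and brings in hydrogen-bond acceptors, yet it gives only a 1.5-fold higher number from compound 1 to compound 4 (0.18 log units; within the scatter) at this aromatic carbon. Trifluoromethyl for methoxycarbonyl likewise leaves no readable difference, with a 1.3-fold lower number from compound 3 to compound 4 (0.10 log units; within the scatter) in the same assay, whereas the exchange of tert-butyl gives a 2.6-fold higher number from compound 2 to compound 4 (0.41 log units; beyond the scatter) and so repeats, at a modest size, the separation already seen for compound 2 and compound 3. No measurement at hand bears on why these steps have the sizes they do.

Open, from the compounds shown here alone, is whether a carboxylic acid, an amine or a longer chain on this carbon would move the number beyond the scatter from compound 1. Going by these compounds, all four compounds share one core, so how these steps would carry over to a different core also remains open.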